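From 2-cyanobenzyl to 4-(trifluoromethyl)benzyl

The compounds below may be only part of what the source reports. "The series", "measured", "known", "first", "only" and "open" are said of these compounds alone.

In a functional assay on B16 cells (Mus musculus) for antiproliferative activity, read by MTT assay, with a stated time of 24 h (a higher number here means a weaker inhibitor, a lower number a stronger inhibitor), compound 1 (`COc1cc(OC)c(-c2coc3cc(OCc4ccccc4F)ccc3c2=O)cc1OC`) gives 1610 nM, compound 2 (`COc1cc(OC)c(-c2coc3cc(OCc4ccc(C#N)cc4)ccc3c2=O)cc1OC`) gives 7000 nM and compound 3 (`COc1cc(OC)c(-c2coc3cc(OCc4ccccc4C#N)ccc3c2=O)cc1OC`) gives 2140 nM. Compound 3 therefore belongs with the lower end of this short series. The data show a 1.3-fold higher number from compound 1 to compound 3 (0.12 log units; within the scatter), but a 3.3-fold lower number from compound 2 to compound 3 (0.51 log units; beyond the scatter).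

Compound 4 (`COc1cc(OC)c(-c2coc3cc(OCc4ccc(C(F)(F)F)cc4)ccc3c2=O)cc1OC`) carries 4-(trifluoromethyl)phenyl in place of 2-cyanophenyl on a saturated chain carbon bound to an oxygen on an aromatic ring.

The nearest guide is compound 2, whose 4-cyanophenyl group goes with 7000 nM, and the measured steps to it are a 4.3-fold higher number from compound 1 to compound 2 (0.64 log units; beyond the scatter) and the reverse of the step to compound 3 given above. Within the data shown here, no trifluoromethyl compound has been measured, so only part of that gap is carried over. In this assay a modest rise is expected, namely a 2.1-fold higher number from compound 3 to compound 4 (0.32 log units; beyond the scatter). The estimated value for compound 4 is 4500 nM, with an expected range of 1800 nM to 10000 nM.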

Compound 4, half-maximal inhibitory concentration: 5400 nM
For compound 4 the middle estimate is 1.2-fold (0.08 log units) below the measured one, within the range that was stated.
By their numbers in this assay, from the lowest: compounds 1 and 3 (each within the scatter of the next); then compounds 4 and 2 (each within the scatter of the next).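

In this assay, the step of a 1.3-fold lower number from compound 2 to compound 4 (0.11 log units; within the scatter) shows that trifluoromethyl in place of cyano leaves the number unresolved from that of the 4-cyanophenyl compound, whereas a 2.5-fold higher number from compound 3 to compound 4 (0.40 log units; beyond the scatter) and a 3.4-fold higher number from compound 1 to compound 4 (0.53 log units; beyond the scatter) set the 4-(trifluoromethyl)phenyl group apart from both 2-cyanophenyl and 2-fluorophenyl. Across these four compounds the groups named with a 2 therefore give the lower numbers and those named with a 4 the higher, with no compound going against this, although only cyano is compared directly in both places. Nothing given here bears on why the numbers divide this way.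

The compounds shown leave open whether 4-fluorophenyl and 2-(trifluoromethyl)phenyl would follow the same division. They also leave open how a phenyl bearing an amine or a carboxylic acid, or a 2-phenylethyl group in place of the benzyl group, would behave.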